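The source may report more compounds than this note shows. Statements on the series, on what has been measured and on what is new or still open speak of the compounds shown alone.

Measured so far:
- compound 1, `Cc1ccc2c(c1)C1(C(=O)N2C)C(C#N)=C(N)Oc2cc3oc(-c4ccccc4)cc(=O)c3c(O)c21`, in a functional assay on A549 cells (Homo sapiens) for antiproliferative activity, read by MTT assay, with a stated time of 48 h (on this read-out lower numbers stand for stronger inhibition and higher numbers for weaker inhibition), gives 7060 nM.
- compound 2, `Cc1ccc2c(c1)C1(C(=O)N2Cc2ccccc2)C(C#N)=C(N)Oc2cc3oc(-c4ccccc4)cc(=O)c3c(O)c21`, in this assay reaches only the limit > 50000 nM.
- compound 3, `Cc1cccc2c1N(Cc1ccccc1)C(=O)C21C(C#N)=C(N)Oc2cc3oc(-c4ccccc4)cc(=O)c3c(O)c21`, in this assay likewise reaches only the limit > 50000 nM.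

Compound 2 thus stands at the edge of what this assay can report: its value is a limit, not a number, and the same holds for compound 3, the limit being (the limit of > 50000 nM in this assay, at which 2 of the 3 values shown sit). Only compound 1 has a measured number.

Compound 4 is `COc1ccc2c(c1)C1(C(=O)N2Cc2ccccc2)C(C#N)=C(N)Oc2cc3oc(-c4ccccc4)cc(=O)c3c(O)c21` and differs from compound 2 by methoxy in place of methyl on an aromatic carbon. For the measured compounds named here, no measured step changes a group on this aromatic ring, so nothing directly tells how large such a swap is. Going by the values given here, the one single-place step measured, an at least 7.0-fold higher number from compound 1 to compound 2 (0.85 log units; beyond the scatter), concerns the benzyl group on the ring nitrogen, which compound 4 keeps unchanged. With compound 2 already at the limit and no evidence that a methoxy for a methyl recovers activity, compound 4 is expected to stay at the limit as well.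

Compound 4 is therefore estimated at 50000 nM, with a range from 20000 nM to 100000 nM. The expected step of a number no higher from compound 2 to compound 4 (the limit leaves the size open) is accordingly none beyond the scatter.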

Compound 4, half-maximal inhibitory concentration: > 50000 nM
Compound 4 was reported as a limit (the forecaster's own chance of this, stated with the estimate: 75%); the middle value lies on the limit itself.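

Compound 2 and compound 4 are both reported only as a limit, not as a number, so the step between them cannot be read: the limit of > 50000 nM in this assay, at which 3 of the 4 values shown sit.

The compounds shown leave open what methoxy in place of methyl does when the parent compound gives a true number, as compound 1 does.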